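A few compounds are considered here, and "the series" means these few. Any claim that something is new, unique, unknown or untested is made for them only; others in the source may bear on it.

Measured compounds in a functional assay on Hs-578T cells (Homo sapiens) for inhibition, read by sulforhodamine B assay, with a stated time of 48 h; on this read-out higher numbers stand for weaker inhibition of growth and lower numbers for stronger inhibition of growth:
compound 1 `COc1cc(-c2nn(-c3cccc(NC(=O)c4cccc(C(F)(F)F)c4)c3)cc2-c2ccncc2)ccc1Cl`: 1070 nM
compound 2 `COc1cc(-c2nn(-c3cccc(NC(=O)Nc4ccc(Cl)c(Cl)c4)c3)cc2-c2ccncc2)ccc1Cl`: 1430 nM
compound 3 `COc1cc(-c2nn(-c3cccc(NC(=O)Nc4cccc(C(F)(F)F)c4)c3)cc2-c2ccncc2)ccc1Cl`: 1230 nM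

Compound 3 sits within the usual scatter of both compound 1 and compound 2, so the three numbers cannot be told apart. Compound 4 `COc1cc(-c2nn(-c3cccc(NC(=O)c4ccc(Cl)c(C(F)(F)F)c4)c3)cc2-c2ccncc2)ccc1Cl` is reached from compound 3 by the change (4-chloro-3-(trifluoromethyl)phenyl in place of (3-(trifluoromethyl)phenyl)amino on a carbonyl carbon). Among the compounds with values here, two measured steps bear on this: a 1.1-fold higher number from compound 1 to compound 3 (0.06 log units; within the scatter), which swaps a carbonyl-bound aryl for an aryl-amino group, and a 1.2-fold lower number from compound 2 to compound 3 (0.07 log units; within the scatter), which swaps the halogens on the outer ring. Both lie within the scatter, so no step beyond the scatter is expected in this assay for compound 4, and its estimated value is 1000 nM, expected to fall between 500 nM and 2000 nM, an expected step of a 1.2-fold lower number from compound 3 to compound 4 (0.09 log units; within the scatter).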

Compound 4, concentration for 50% growth inhibition: 2170 nM
Beside the measured number, compound 4's estimate is 2.2-fold (0.34 log units) below it; measured number above the stated range.
By their numbers in this assay, from the lowest: compounds 1, 3, 2 and 4 (each within the scatter of the next, the first and the last beyond it).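

In this assay, within the data shown here, this is the first step beyond the scatter, though a modest one: chloro in place of hydrogen on an aromatic carbon (a 2.0-fold higher number from compound 1 to compound 4 (0.31 log units; beyond the scatter)). Exchanging either aryl-amino group on the carbonyl carbon for 4-chloro-3-(trifluoromethyl)phenyl stays within the scatter (a 1.8-fold higher number from compound 3 to compound 4 (0.25 log units; within the scatter)) and (a 1.5-fold higher number from compound 2 to compound 4 (0.18 log units; within the scatter)). Nothing available explains the chloro step. On these data alone, whether fluoro, methyl or methoxy on that aromatic carbon would give a similar step remains open. So does the effect of an amine there.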